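The compounds below may be only part of what the source reports. "The series", "measured", "known", "first", "only" and "open" are said of these compounds alone.

In an ADME assay on microsomes from liver (Homo sapiens) for metabolic stability, read by LC-MS, with NADPH named in the record, with a stated time of 60 min, tested at 1 uM, in the absence of a further agent (a higher number here means that more of the compound is left, a lower number that less of the compound is left), compound 3 `COc1ccc(-c2c(C)nc3c(N4CC[C@@H](NS(=O)(=O)C5CC5)C4)cc(C)nn23)cc1OC` gives > 95%, which is a limit and not a number. Compound 1 `COc1ccc(-c2c(C)nc3c(N4CC[C@@H](NC(=O)c5ccccc5)C4)cc(C)nn23)cc1OC`, with phenyl on a carbonyl carbon, also gives a limit, > 95%. Compound 2 `COc1ccc(-c2c(C)nc3c(N4CC[C@@H](NC(=O)C(F)(F)F)C4)cc(C)nn23)cc1OC` gives a limit as well, > 95%. The evidence so far is the limit of > 95% in this assay, at which 3 of the 3 values shown sit.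

Compound 4 `COc1ccc(-c2c(C)nc3c(N4CC[C@@H](NS(=O)(=O)c5ccccc5)C4)cc(C)nn23)cc1OC` has phenyl in place of cyclopropyl on a sulfonyl sulfur. The measured steps that bear on this change are a step that the two limits leave unreadable from compound 1 to compound 3, a step that the two limits leave unreadable from compound 1 to compound 2 and a step that the two limits leave unreadable from compound 2 to compound 3. Among the compounds with values here, none of them has a readable size, so the series offers no measured step for this exchange. In this assay, no step beyond the scatter is expected, in either direction. The expected change is a step that the limit leaves unreadable from compound 3 to compound 4. For compound 4 the estimate is 96%, with an expected range of 84% to 100%.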

Compound 4, percent of the compound remaining: > 95%
Compound 4 gave a limit, no number; the forecaster's own chance of this, stated with the estimate: 65%; the middle value lies beyond the limit too.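

Within the data shown here, compound 4 gives a limit and not a number, so no step between it and compound 1, compound 2 or compound 3 can be read in this assay: the limit of > 95% in this assay, at which 4 of the 4 values shown sit. The compounds shown leave open whether benzoyl, (trifluoromethyl)carbonyl, cyclopropylsulfonyl and phenylsulfonyl on the amine nitrogen differ at all in this read-out.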